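Phenyl Replaces Ethyl on the Sulfur-Bound Chain

A few compounds are considered here, and "the series" means these few. Any claim that something is new, unique, unknown or untested is made for them only; others in the source may bear on it.

Compound 1, `CN(C)c1nc(N)nc2c1ncn2/C=C1/CC1(CO)CO`: in an ADME assay on Akata cells (Homo sapiens) for cytotoxicity, with a stated time of 7 days (a lower number here means that less compound is tolerated, a higher number that more compound is tolerated), compound 1 gives > 24000 nM, which is a limit of the assay.
Compound 2, `CCCSc1nc(N)nc2c1ncn2/C=C1/CC1(CO)CO`: in this assay compound 2 gives > 20000 nM, again a limit.

Going by the values given here, the single measured step, a step that the two limits leave unreadable from compound 1 to compound 2, cannot be sized because the limit of > 20000 nM in this assay, at which 1 of the 2 values shown sits, and the limit of > 24000 nM in this assay, at which 1 of the 2 values shown sits, cap both values. Among the compounds with values here, compound 2 therefore stands at a limit, as does the only other value. Compound 3, `Nc1nc(SCc2ccccc2)c2ncn(/C=C3/CC3(CO)CO)c2n1`, differs from compound 2 by phenyl in place of ethyl on a saturated chain carbon bound to a sulfur. Within the data shown here, no measured step bears on this change. Compound 3 is expected at 20000 nM, ranging from 7000 nM to 50000 nM, so the expected step of a number no higher from compound 2 to compound 3 (the limit leaves the size open) is none beyond the scatter, most likely another limit.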

Compound 3, half-maximal cytotoxic concentration: > 20000 nM
Compound 3 was reported as a limit (the forecaster's own chance of this, stated with the estimate: 65%); the middle value sits exactly at the limit.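

Going by these compounds alone, compound 1, compound 2 and compound 3 all stand at limits of this assay, so no step among them can be read. Going by these compounds, whether dimethylamino, propylsulfanyl and benzylsulfanyl differ at all in cytotoxicity remains open.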